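Hydroxyphenyl exchange from compound 2 to compound 3

The source may report more compounds than this note shows. Statements on the series, on what has been measured and on what is new or still open speak of the compounds shown alone.

In an ADME assay on PC-12 cells (Rattus norvegicus) for cytotoxicity, read by WST assay, with a stated time of 24 h (a higher number here means that more compound is tolerated, a lower number that less compound is tolerated), compound 1 `O=C(/C=C/c1cccc(O)c1O)CC(=O)/C=C/c1cccc(O)c1O` gives 39000 nM and compound 2 `O=C(/C=C/c1cccc(O)c1)CC(=O)/C=C/c1cccc(O)c1O` gives 38000 nM with no separation beyond the scatter. For the measured compounds named here, the only measured step is a 1.0-fold lower number from compound 1 to compound 2 (0.01 log units; within the scatter) for hydrogen in place of hydroxy on an aromatic carbon, and it stays within the scatter. Compound 3 `O=C(/C=C/c1ccc(O)cc1)CC(=O)/C=C/c1cccc(O)c1O` differs from compound 2 by 4-hydroxyphenyl in place of 3-hydroxyphenyl on a double-bonded chain carbon bound to a double-bonded chain carbon and keeps the same atoms, joined differently. Going by the values given here, no measured pair shows this exchange directly, so the evidence is indirect. Among the compounds with values here, with a 1.0-fold lower number from compound 1 to compound 2 (0.01 log units; within the scatter) as the only guide, no step beyond the scatter is expected in this assay for this exchange. The estimated step is a 1.1-fold lower number from compound 2 to compound 3 (0.02 log units; within the scatter) and carries no firm direction. For compound 3 the estimate is 36000 nM with an expected range from 16000 nM to 75000 nM in this measurement.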

Compound 3, half-maximal cytotoxic concentration: 8500 nM
For compound 3 the middle estimate is 4.2-fold (0.63 log units) above the measured one; measured number outside the range, below it.
By their numbers in this assay, from the lowest: compound 3; then compounds 2 and 1 (each within the scatter of the next).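

In this assay, for the compounds shown here, the exchange of 3-hydroxyphenyl for 4-hydroxyphenyl on a double-bonded chain carbon bound to a double-bonded chain carbon gives the first step beyond the scatter (a 4.5-fold lower number from compound 2 to compound 3 (0.65 log units; beyond the scatter)), although the two compounds have the same atoms, joined differently. Replacing 2,3-dihydroxyphenyl at this place with 4-hydroxyphenyl gives a step of similar size (a 4.6-fold lower number from compound 1 to compound 3 (0.66 log units; beyond the scatter)), so among these three compounds, only the change that yields 4-hydroxyphenyl moves the number beyond the scatter. No available evidence accounts for this step.

Going by these compounds, whether a 4-aminophenyl or 4-methoxyphenyl group at this place would track with compound 3 remains open. Also open, on these data alone, is whether changing the 2,3-dihydroxyphenyl group shared by all three compounds would shift the number.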